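Removing the chloro on the anilino ring: compound 4

The source may hold more compounds than are shown below. What is called first, only, known or untested is meant among the compounds shown, and "the series" means these compounds.

Measured compounds:
compound 1 `C#CCSc1nc(Nc2ccccc2Cl)c(C#N)c(-c2ccccc2)n1` 24200 nM
compound 2 `C#CCSc1nc(Nc2cccc(Cl)c2)c(C#N)c(-c2ccccc2)n1` > 128000 nM
compound 3 `N#Cc1c(Nc2ccccc2Cl)nc(SCc2cn(Cc3ccccc3Cl)nn2)nc1-c1ccccc1` 1950 nM

In a functional assay on MCF7 cells (Homo sapiens) for inhibition, read by MTT assay, with a stated time of 72 h (on this read-out lower numbers stand for stronger inhibition and higher numbers for weaker inhibition), compound 1 gives 24200 nM. Compound 2 reaches only the assay limit, > 128000 nM, which is a limit and not a number (the limit of > 128000 nM in this assay, at which 1 of the 3 values shown sits). Compound 3 gives 1950 nM, the lowest number shown, compound 1 being the nearest.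

Compound 4 `N#Cc1c(Nc2ccccc2)nc(SCc2cn(Cc3ccccc3Cl)nn2)nc1-c1ccccc1` differs from compound 3 by hydrogen in place of chloro on an aromatic carbon. Among the measured compounds shown here, the only measured step, an at least 5.2-fold higher number from compound 1 to compound 2 (0.72 log units; beyond the scatter), concerns the same chlorophenyl but moves the chloro rather than removing it. That step suggests the 2-chlorophenyl contributes, so for compound 4 a modest weakening is expected, a 2.6-fold higher number from compound 3 to compound 4 (0.41 log units; beyond the scatter). Compound 4 is therefore estimated at 5000 nM, within 1500 nM to 20000 nM.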

Compound 4, half-maximal inhibitory concentration: > 64000 nM
Compound 4: only a limit was reported (the forecaster's own chance of this, stated with the estimate: 5%); middle value at least 12-fold (1.10 log units) from the limit.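

In this assay, hydrogen in place of chloro on an aromatic carbon gives an at least 32-fold higher number from compound 3 to compound 4 (1.51 log units; beyond the scatter), a large loss beyond the scatter. Compound 4 stands at a limit, > 64000 nM, and not at a number. The earlier step only moved the chloro, in the compounds with the shorter sulfur substituent, whereas this one shows that the number of compound 3 depends on having a chloro at this place.

As far as these compounds go, whether bromo, fluoro or methyl could replace the chloro here stays open. The compounds shown give no cause for the loss.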